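Aryl variation on the sulfonyl sulfur: outlook for compound 4

The source may report more compounds than this note shows. Statements on the series, on what has been measured and on what is new or still open speak of the compounds shown alone.

Three analogues sharing one core have been run in a functional assay (Cavia porcellus) with sulfonylurea receptors; K-ATP channels (Homo sapiens) as the target; on this read-out lower numbers stand for stronger inhibition and higher numbers for weaker inhibition. Compound 1 `CC(O)(C(=O)Nc1ccc(S(=O)(=O)c2cccc(F)c2)cc1)C(F)(F)F` gives 3400 nM. Compound 2 `CC(O)(C(=O)Nc1ccc(S(=O)(=O)c2ccccc2)c(C#N)c1)C(F)(F)F` gives 3800 nM. Compound 3 `CC(O)(C(=O)Nc1ccc(C#N)c(S(=O)(=O)c2ccccc2)c1)C(F)(F)F` gives 2600 nM. Compound 1 holds the second highest of the three numbers; its nearest neighbour is compound 2 and its furthest is compound 3, and both gaps lie within the usual scatter, so no order among the three can be read. Compound 4 `COc1ccc(S(=O)(=O)c2ccc(NC(=O)C(C)(O)C(F)(F)F)cc2)cc1` is not yet measured. It differs from compound 1 by 4-methoxyphenyl in place of 3-fluorophenyl on a sulfonyl sulfur. For the measured compounds named here, no measured pair isolates this change, and the measured numbers show no swing beyond the scatter, so in this assay the expected step of a 1.1-fold lower number from compound 1 to compound 4 (0.03 log units; within the scatter) is taken as none beyond the scatter. Compound 4 is accordingly estimated at 3200 nM, with a range from 1200 nM to 8500 nM.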

Compound 4, half-maximal inhibitory concentration: > 30000 nM
Compound 4 gave a limit, no number; the forecaster's own chance of this, stated with the estimate: 5%; at least 9.3-fold (0.97 log units) between middle value and limit.
By their numbers in this assay, from the lowest: compounds 3, 1 and 2 (each within the scatter of the next). At a limit, above all of these: compound 4.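

In this assay compound 4 reads > 30000 nM, which is a limit of the assay and not a number. Exchanging the 3-fluorophenyl group on a sulfonyl sulfur for a 4-methoxyphenyl group gives an at least 8.8-fold higher number from compound 1 to compound 4 (0.94 log units; beyond the scatter), so aryl choice at this position can matter, which compound 1, compound 2 and compound 3 alone could not show. The size of this step is bounded, not fixed: the limit of > 30000 nM in this assay, at which 1 of the 4 values shown sits.

No pair shown separates losing the fluorine from gaining the methoxy group. As far as these compounds go, how an aryl group carrying an amine or a carboxylic acid would read on the sulfonyl sulfur remains open.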